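Moving the chlorine around the pendant phenyl ring

This account rests on a few compounds, and the source may have more. Where it says the series, first, only, none or still open, it means among the compounds named here.

Among the measured compounds shown here, compound 1 `C#CCSc1nc(Sc2nnnn2CCN(C)C)c(C#N)c(-c2cccc(Cl)c2)n1` is one of three compounds measured in a functional assay on PC-9 cells (Homo sapiens) for antiproliferative activity, read by MTT assay (on this read-out lower numbers stand for stronger inhibition and higher numbers for weaker inhibition), where compound 1 gives 6480 nM. Compound 2 `C#CCSc1nc(Sc2nccs2)c(C#N)c(-c2ccc(C)cc2)n1` gives 1110 nM, and compound 3 `C#CCSc1nc(Sc2nccs2)c(C#N)c(-c2ccc(Br)cc2)n1` gives 12100 nM; compound 1 thus stands second highest, within the scatter of compound 3 and beyond it from compound 2. For the measured compounds named here, the only single-point step measured so far, an 11-fold higher number from compound 2 to compound 3 (1.04 log units; beyond the scatter), concerns bromo in place of methyl on an aromatic carbon, that is an exchange of one group for another, not a shift of a group to a different carbon. Compound 4 `C#CCSc1nc(Sc2nnnn2CCN(C)C)c(C#N)c(-c2ccc(Cl)cc2)n1` differs from compound 1 by 4-chlorophenyl in place of 3-chlorophenyl on an aromatic carbon. Going by the values given here, no measured step covers such a relocation, so the direction is open; the large step from compound 2 to compound 3 only shows that the pendant ring matters. Compound 4 is therefore expected to sit near compound 1, with a step of about a 1.1-fold lower number from compound 1 to compound 4 (0.03 log units; within the scatter). The estimate for compound 4 in this assay is 6000 nM, within a range from 2500 nM to 15000 nM.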

Compound 4, half-maximal inhibitory concentration: 5300 nM
For compound 4 the middle estimate is 1.1-fold (0.05 log units) above the measured one; the measured number falls inside the stated range.
By their numbers in this assay, from the lowest: compound 2; then compounds 4, 1 and 3 (each within the scatter of the next, the first and the last beyond it).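

In this assay, the relocation of the chlorine gives a 1.2-fold lower number from compound 1 to compound 4 (0.09 log units; within the scatter), so the 3-chlorophenyl and 4-chlorophenyl compounds cannot be told apart on this read-out. The earlier compounds shown here showed only an exchange of one group for another at this ring, an 11-fold higher number from compound 2 to compound 3 (1.04 log units; beyond the scatter), and that step was large; here, with the rest of compound 1 kept, where the chlorine sits on the pendant ring makes no readable difference for this pair. Nothing given here explains why the two isomers read alike.

The compounds shown leave open whether an amine, a methoxy group or a carboxylic acid on the pendant phenyl ring would read differently from chlorine. They also leave open whether the exchange of methyl for bromo would produce a step of the same size on the core of compound 1.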